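The compounds below may be only part of what the source reports. "The series", "measured", "known", "first", "only" and "open" are said of these compounds alone.

Measured so far:
Compound 1 `COc1ccc(N)c(C2=NN(C(C)=O)C(C)(C)S2)c1`: 77.1%
Compound 2 `CCC(=O)N1N=C(c2cc(OC)ccc2N)SC1(C)C`: 73%

In an assay on isolated protein for inhibition of Nitric oxide synthase, inducible (Homo sapiens), read by scintillation counting, with a stated time of 30 min, tested at 50 uM (a lower number here means less inhibition, a higher number more inhibition at the concentration tested (going by the name of the read-out)), compound 1 gives 77.1%, and compound 2 gives 73%. Within the data shown here, these are the only two numbers known, and they lie within the scatter of each other, so compound 1 cannot be set apart from compound 2 on the numbers alone.

Compound 3 `COc1ccc(N)c(C2=NN(C(=O)C3CCC3)C(C)(C)S2)c1` has not been measured. It differs from compound 1 by cyclobutyl in place of methyl on a carbonyl carbon. Among the measured compounds shown here, the one measured step that bears on this is a number 4.1 percentage points lower from compound 1 to compound 2 (within the scatter), where the acyl group on the ring nitrogen also grew by one carbon with no change beyond the scatter. The change to compound 3 is larger, but of the same kind, and nothing measured here points to a gain or a loss.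

The expected step is therefore a number 5.1 percentage points lower from compound 1 to compound 3 (within the scatter), meaning compound 3 is estimated at 72%, with a range from 58% to 84%.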

Compound 3, a percentage reported as inhibition, at one concentration (the size of the read-out at that concentration, not a potency): 57.8%
Compound 3: middle estimate off by 14.2 percentage points, on the high side; the measured number lies below the stated range.
By their numbers in this assay, from the lowest: compound 3; then compounds 2 and 1 (each within the scatter of the next).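

In this assay the choice of group on this carbonyl carbon turns out to matter: cyclobutyl in place of methyl (a number 19.3 percentage points lower from compound 1 to compound 3 (beyond the scatter)) and cyclobutyl in place of ethyl (a number 15.2 percentage points lower from compound 2 to compound 3 (beyond the scatter)) both come with less inhibition at the concentration tested. Among these three compounds, then, the position does not take every change without effect, as the step from methyl to ethyl alone (a number 4.1 percentage points lower from compound 1 to compound 2 (within the scatter)) might have suggested. Nothing available explains why inhibition falls with cyclobutyl.

The compounds shown leave open whether the fall goes with the ring itself or with the carbon count, which a longer open chain such as butyl or a smaller ring such as cyclopropyl on the same carbonyl carbon could separate. Also open, going by these compounds, is how an amine in that place would read, and, as each number comes from a single concentration, how potency itself changes across the series.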